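Swapping cyano for acetyl in a small series

The source may report more compounds than this note shows. Statements on the series, on what has been measured and on what is new or still open speak of the compounds shown alone.

Compound 1 `CCC(=O)N(c1ccc(C)cc1)C1CCCC1N(C)C` gives 10 mg/kg; 10 mg/kg (2 entries)
Compound 2 `CCC(=O)N(c1ccc(Br)cc1)C1CCCC1N(C)C` gives 3 mg/kg
Compound 3 `CCC(=O)N(c1ccc(C#N)cc1)C1CCCC1N(C)C` gives 40 mg/kg

These numbers come from a functional assay on the whole organism for antagonist activity, with Mus musculus as the target; a lower number here means that less compound is needed, a higher number that more compound is needed for the effect. Compound 3 has the highest number of the three, so it takes the largest dose here. Compound 4 `CCC(=O)N(c1ccc(C(C)=O)cc1)C1CCCC1N(C)C` has not yet been measured. It replaces the cyano group of compound 3 with an acetyl group on an aromatic carbon, para to a large group: acetyl in place of cyano on an aromatic carbon. The counts of hydrogen-bond donors and acceptors stay the same.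

Going by the values given here, only one measured step bears on this change. It is a 13-fold higher number from compound 2 to compound 3 (1.12 log units; beyond the scatter), with cyano in place of bromo on an aromatic carbon. This large step, well beyond the scatter, shows that a swap at this carbon can shift the dose strongly. Among the compounds with values here, it says nothing directly about acetyl, though, and no measured compound carries that group. With so little to go on, no step beyond the scatter is expected in this assay, and a slightly lower number is the best guess. The expected change is a 1.6-fold lower number from compound 3 to compound 4 (0.20 log units; within the scatter). Compound 4 is estimated at 25 mg/kg, with an expected range from 8 mg/kg to 80 mg/kg.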

Compound 4, dose for half-maximal effect: 40 mg/kg
Estimate against measurement, compound 4: 1.6-fold (0.20 log units) below, within the range that was stated.
By their numbers in this assay, from the lowest: compound 2; then compounds 3 and 4 (each within the scatter of the next).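

In this assay, acetyl in place of cyano on this aromatic carbon, para to a large group, gives no change at the digits printed from compound 3 to compound 4 (within the scatter), so the position does not separate these two groups, although they differ in their atoms and bonds. Acetyl in place of bromo gives a 13-fold higher number from compound 2 to compound 4 (1.12 log units; beyond the scatter), a step of the same printed size as a 13-fold higher number from compound 2 to compound 3 (1.12 log units; beyond the scatter), which means the large gap from compound 2 is not confined to the nitrile. The data offer no measurement that explains the match between cyano and acetyl, or the gap between these two groups and bromo.

Going by these compounds alone, compound 1, with a methyl group at this carbon, gives 10 mg/kg; 10 mg/kg (2 entries), a value that falls between those of compound 2 and compound 4, so the series so far holds only a few points along this range. Going by these compounds, it remains open whether other groups at this carbon, such as chlorine, methoxy, an amine or a carboxylic acid, would give doses closer to that of compound 2 or to those of compound 3 and compound 4.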